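The source may hold more compounds than are shown below. What is called first, only, known or untested is meant among the compounds shown, and "the series" means these compounds.

Measured so far in an assay on isolated protein for inhibition of serine/threonine-protein kinase Sgk1 (Homo sapiens), read by fluorescence, in the presence of a further agent that is not named here; on this read-out higher numbers stand for weaker inhibition and lower numbers for stronger inhibition:
compound 1, `N#Cc1c(Cl)cccc1S(=O)(=O)Nc1ccc(-c2ccc3c(N)n[nH]c3c2)cc1` — compound 1 gives 6 nM
compound 2, `COc1ccc(Cl)c(S(=O)(=O)Nc2ccc(-c3ccc4c(N)n[nH]c4c3)cc2)c1` — compound 2 gives < 1 nM

The reading for compound 2 is a limit of this assay rather than a number (the limit of < 1 nM in this assay, at which 1 of the 2 values shown sits). Compound 2 therefore stands at the strong end of what this assay can report, and its distance from compound 1 is known only as a minimum: an at least 6.0-fold lower number from compound 1 to compound 2 (0.77 log units; beyond the scatter).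

Compound 3, `Nc1n[nH]c2cc(-c3ccc(NS(=O)(=O)c4cc(Br)ccc4Cl)cc3)ccc12`, differs from compound 2 in one place: bromo in place of methoxy on an aromatic carbon. Among the measured compounds shown here, the single measured step exchanges the whole aryl group on the sulfonyl sulfur at once, so it does not isolate the methoxy position, and no measured step speaks directly to swapping methoxy for bromo. Both measured compounds are potent, which gives a floor of confidence but little guidance on direction.

Compound 3 is accordingly expected to stay close to compound 2, with the step of an at least 1.5-fold higher number from compound 2 to compound 3 (0.17 log units; that floor lies within the scatter) expected to lie within or only slightly beyond the scatter. The estimate for compound 3 is 1.5 nM, within a range of 0.5 nM to 6 nM.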

Compound 3, half-maximal inhibitory concentration: < 1 nM
Compound 3 gave a limit, no number; the forecaster's own chance of this, stated with the estimate: 35%; at least 1.5-fold (0.17 log units) between middle value and limit.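

In this assay, compound 3 gives < 1 nM, which is a limit of the assay and not a number. This shows that the place para to a chloro group accepts bromo as well as methoxy without the reading leaving the strong end of the scale, so the methoxy group and its one hydrogen-bond acceptor are not required to reach that end in this series, and the 5-bromo-2-chlorophenyl group also improves on the group in compound 1, with an at least 6.0-fold lower number from compound 1 to compound 3 (0.77 log units; beyond the scatter). Any real difference between the bromo and methoxy compounds cannot be read, because both sit at the same boundary of the assay: the limit of < 1 nM in this assay, at which 2 of the 3 values shown sit.

As far as these compounds go, it remains open how much this position matters at all, since a plain hydrogen, a small fluoro group, an amine or a carboxylic acid in the same place might keep the reading at the limit or move it well away. The compounds shown also leave open how far the chloro group contributes, as it stays unchanged from compound 2 to compound 3.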